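Swapping a methyl for a methoxy on the phenyl ring

A few compounds are considered here, and "the series" means these few. Any claim that something is new, unique, unknown or untested is made for them only; others in the source may bear on it.

Of the compounds shown here, two with a shared core have so far been measured in an assay on cells for inhibition of sodium- and chloride-dependent glycine transporter 1 (Homo sapiens); a lower number here means that less compound is needed, a higher number that more compound is needed for the effect. Compound 1 `CN1CCCC(NC(=O)c2ccc(C(F)(F)F)cc2F)(c2ccccc2)C1` gives 9900 nM. Compound 2 `COc1cc(C(F)(F)F)cc(SC)c1C(=O)NC1(c2ccc(C)cc2)CCCN(C)C1` gives 230 nM, the lower of the two numbers, and the gap to compound 1 lies beyond the usual scatter. The two compounds differ in several places at once, however, so no single change can be credited for that gap.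

Compound 3 `COc1cccc(C2(NC(=O)c3c(OC)cc(C(F)(F)F)cc3SC)CCCN(C)C2)c1` has not yet been measured in this assay. It differs from compound 2 in one place only: 3-methoxyphenyl in place of 4-methylphenyl on a saturated ring carbon. Among the measured compounds shown here, no measured pair shows this particular change, so its effect has to be judged without a precedent. Because compound 2 already stands at 230 nM and everything else in it is kept, the swap of a methyl for a methoxy on that phenyl ring is expected to move the number only modestly, in either direction or not beyond the scatter at all. The expected step is a 1.3-fold higher number from compound 2 to compound 3 (0.12 log units; within the scatter). Compound 3 is therefore estimated at 300 nM, within a range from 100 nM to 1000 nM.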

Compound 3, half-maximal effective concentration: 110 nM
Estimate against measurement, compound 3: 2.7-fold (0.44 log units) above; low and high end bracket the measured number.
By their numbers in this assay, from the lowest: compound 3; then compound 2; then compound 1.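

The phenyl group on the saturated ring carbon is a place where one change alone shifts the number in this assay: the swap of 4-methylphenyl for 3-methoxyphenyl gives a 2.1-fold lower number from compound 2 to compound 3 (0.32 log units; beyond the scatter), a modest step that still lies beyond the scatter. Among the compounds shown here, compounds 1 and 2 differ in several places at once, so this is the first step that can be tied to a single site on the shared core. It also shows that this position accepts the larger 3-methoxyphenyl group, with 8 heavy atoms against 7 and 1 hydrogen-bond acceptor against 0, with no loss in this assay.

This single swap changes both the group and the number in its name, so the step does not separate the methoxy group from its placement; a 3-methylphenyl or a 4-methoxyphenyl at the same carbon would be needed to pull the two apart. The compounds shown offer no measurement that explains why the number falls with this change.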